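Turning One Stereocentre of Compound 1

A few compounds are considered here, and "the series" means these few. Any claim that something is new, unique, unknown or untested is made for them only; others in the source may bear on it.

For the measured compounds named here, in a physicochemical assay for lipophilicity (a lower number here means a more polar compound, a higher number a more lipophilic compound), compound 1 `CNC(=O)c1cc(C(=O)NC2CC2)cn([C@H](C)c2ccccc2)c1=O` gives 3.5, the highest of the three numbers so far. Compound 3 `CNC(=O)c1cc(C(=O)N[C@H]2CC[C@H](O)CC2)c([C@@H](C)c2ccccc2Cl)o1` gives 3.1 and compound 2 `CNC(=O)c1cc(C(=O)NC2CC2)cn(Cc2cccc3[nH]ccc23)c1=O` gives 2.9, and both lie lower than compound 1 by more than the scatter. Compound 4 `CNC(=O)c1cc(C(=O)NC2CC2)cn([C@@H](C)c2ccccc2)c1=O` is still unmeasured. Its relation to compound 1 is simple: the two compounds have the same atoms and bonds and differ only in configuration as drawn: 1 of 1 stereo elements differ; a stereocentre at a saturated chain carbon is drawn R in compound 1 and S in compound 4. Going by the values given here, no measured pair here shows a change of this kind, so the expectation rests on the structures alone. With the same atoms and bonds, compound 1 at 3.5 is the natural guide. The expected step of no change at the digits printed from compound 1 to compound 4 (within the scatter) is none beyond the scatter. For compound 4 the estimated value is 3.5, within an expected range from 3.2 to 3.8.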

Compound 4, distribution coefficient: 3.3
Compound 4: the middle estimate sits 0.20 log units above what was measured; the measured number falls inside the stated range.
By their numbers in this assay, from the lowest: compounds 2, 3, 4 and 1 (each within the scatter of the next, the first and the last beyond it).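

In this assay, turning the stereocentre at the saturated chain carbon from R to S gives a number 0.20 log units lower from compound 1 to compound 4 (within the scatter). For the compounds shown here, this is the first pair in the set that can be compared directly, and the comparison is clean because only one feature separates the two compounds: the fact that compounds 1 and 4 differ only in the configuration as drawn. At this position, the two drawn configurations are not told apart by this measurement.

On these data alone, whether that holds for other compounds stays open. A carboxylic acid or an amine on the shared core, or a longer chain at the stereocentre, could behave differently.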